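Adding a phenyl to the chain of compound 2

A few compounds are considered here, and "the series" means these few. Any claim that something is new, unique, unknown or untested is made for them only; others in the source may bear on it.

Compound 1 `CC1=NN(C(=O)CCc2ccccc2)C(c2cc(Br)ccc2O)C1` gives 21200 nM
Compound 2 `CCC(=O)N1N=C(C)CC1c1cc(Br)cc(Br)c1O` gives 38600 nM

Only these two compounds have been measured in a functional assay on MGC-803 cells (Homo sapiens) for cytotoxicity, read by MTT assay, with a stated time of 48 h; a lower number here means a stronger inhibitor, a higher number a weaker inhibitor. Compound 2 (38600 nM) lies within the scatter of compound 1 (21200 nM), so the two values show no clear separation. Compound 3 `CC1=NN(C(=O)CCc2ccccc2)C(c2cc(Br)cc(Br)c2O)C1` has not yet been measured. It differs from compound 2 by one change (phenyl in place of hydrogen on a saturated chain carbon, two bonds along the chain from a carbonyl carbon): phenyl in place of hydrogen on a saturated chain carbon, two bonds along the chain from a carbonyl carbon. The same difference can be read as ethyl to phenethyl.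

Among the measured compounds shown here, no measured step shows what a change of this kind does in this assay, so any forecast remains loose. Only a modest move toward a lower number is expected, and it may not go beyond the scatter. The estimated move is a 1.9-fold lower number from compound 2 to compound 3 (0.29 log units; within the scatter) (an expectation, not a result). For compound 3 the expected value is 20000 nM, with an estimated range from 8000 nM to 45000 nM (the wide span reflects how little has been measured).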

Compound 3, half-maximal inhibitory concentration: 17100 nM
Compound 3: the middle estimate sits 1.2-fold (0.07 log units) above what was measured, within the range that was stated.
By their numbers in this assay, from the lowest: compounds 3, 1 and 2 (each within the scatter of the next, the first and the last beyond it).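

The phenyl position now has a measured step: in this assay, replacing hydrogen with phenyl on a saturated chain carbon, two bonds along the chain from a carbonyl carbon, gives a 2.3-fold lower number from compound 2 to compound 3 (0.35 log units; beyond the scatter). Read as ethyl to phenethyl, this change produces a modest shift that just clears the usual scatter, something the two earlier compounds could not show because they differ in more than one place. The other new step, bromo in place of hydrogen on an aromatic carbon, gives a 1.2-fold lower number from compound 1 to compound 3 (0.09 log units; within the scatter), so on the phenethyl series this bromo has no effect that can be told apart from the scatter, and nothing measured here explains either step.

As far as these compounds go, each reading rests on a single pair of compounds, so it remains open whether the phenyl step would hold on the core of compound 1. From the compounds shown here alone, it is also open whether a plain butyl chain would match the phenyl, or whether a phenyl carrying an amine or a carboxylic acid would move the number further in this assay.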